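Swapping a bulky tert-butoxy for a chloro substituent

The compounds below may be only part of what the source reports. "The series", "measured", "known", "first", "only" and "open" are said of these compounds alone.

Measured compounds:
- compound 1, `CCCCOc1ccc(/C=C2\CCCN=C2c2cccnc2)cc1`, in an assay on membranes from brain for displacement of a labelled ligand from Neuronal acetylcholine receptor; alpha4/beta2 (Rattus norvegicus), with a stated time of 3 h (on this read-out lower numbers stand for stronger inhibition and higher numbers for weaker inhibition), compound 1 gives 1960 nM
- compound 2, `C(=C1\CCCN=C1c1cccnc1)\c1ccc(-n2ccnn2)cc1`, in this assay compound 2 gives 520 nM
- compound 3, `CC(C)(C)Oc1ccc(/C=C2\CCCN=C2c2cccnc2)cc1`, in this assay compound 3 gives 2170 nM

Compound 3 carries the highest number of the three. Its nearest neighbour is compound 1, with a 1.1-fold higher number from compound 1 to compound 3 (0.04 log units; within the scatter), a gap within the scatter; compound 2 lies furthest away, with a 4.2-fold higher number from compound 2 to compound 3 (0.62 log units; beyond the scatter). The one clear step among these three is a 3.8-fold lower number from compound 1 to compound 2 (0.58 log units; beyond the scatter), where a small aromatic ring replaces a chain on an aromatic carbon.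

Compound 4, `Clc1ccc(/C=C2\CCCN=C2c2cccnc2)cc1`, differs from compound 3 in one place: chloro in place of tert-butoxy on an aromatic carbon. For the measured compounds named here, none of the measured steps involves a chloro group, so only an indirect reading is possible. The two alkoxy compounds sit close together, while the smaller triazolyl in compound 2 brought the number down. A small substituent is therefore expected to give a modest decrease, estimated as a 2.2-fold lower number from compound 3 to compound 4 (0.34 log units; beyond the scatter), though a result within the scatter would not be surprising. Compound 4 is estimated at 1000 nM, with a range from 300 nM to 3500 nM.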

Compound 4, inhibition constant: 970 nM
The estimate for compound 4 lay 1.0-fold (0.01 log units) above the measured number; the range from low to high includes it.
By their numbers in this assay, from the lowest: compounds 2 and 4 (each within the scatter of the next); then compounds 1 and 3 (each within the scatter of the next).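

At this aromatic carbon in this assay, chloro, with its single heavy atom, gives a lower number than either of the two larger alkoxy groups, with a 2.2-fold lower number from compound 3 to compound 4 (0.35 log units; beyond the scatter) and a 2.0-fold lower number from compound 1 to compound 4 (0.31 log units; beyond the scatter). The drop seen earlier with 1H-1,2,3-triazol-1-yl therefore does not need a ring at this place, and chloro and that triazolyl group cannot be separated, with a 1.9-fold higher number from compound 2 to compound 4 (0.27 log units; within the scatter), a step within the scatter. Nothing available here explains why these groups differ.

From the compounds shown here alone, it remains open whether a smaller group still, such as fluoro or a lone hydrogen, would fall with chloro and the triazolyl group or move further from the alkoxy pair. Going by these compounds, an amine or a carboxylic acid at this carbon is equally open.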